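A few compounds are considered here, and "the series" means these few. Any claim that something is new, unique, unknown or untested is made for them only; others in the source may bear on it.

Compound 1 `COc1ccc(-c2ccc(-c3ccc(-c4nc5cc(C)ccc5[nH]4)cc3)cc2)cc1OC` and compound 2 `COc1ccc(-c2ccc(-c3ccc(-c4nc5ccccc5[nH]4)cc3)cc2)cc1` have both been tested in a functional assay on A549 cells (Homo sapiens) for inhibition, read by sulforhodamine B assay (on this read-out lower numbers stand for stronger inhibition of growth and higher numbers for weaker inhibition of growth), so far. There, compound 1 gives 2100 nM and compound 2 gives 38100 nM as the higher of the two numbers. Compound 2 therefore shows the weaker growth inhibition, and its gap to compound 1 lies beyond the usual scatter. The two compounds differ in more than one place, so that gap cannot be assigned to any single change.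

Compound 3 `COc1ccc(-c2ccc(-c3ccc(-c4nc5ccccc5[nH]4)cc3)cc2)cc1OC` differs from compound 2 in one place: methoxy in place of hydrogen on an aromatic carbon. This turns 4-methoxyphenyl into 3,4-dimethoxyphenyl, a group also found in compound 1. Among the compounds with values here, no measured pair isolates this change, so its size remains a judgement. Stronger inhibition beyond the scatter is expected, resting on compound 1 at 2100 nM with that same group. Part of the gap may belong to the other difference, so only part of it is expected here. The estimated change is a 6.4-fold lower number from compound 2 to compound 3 (0.80 log units; beyond the scatter) in this direction. For compound 3 the estimated value is 6000 nM with an expected range from 1800 nM to 20000 nM in this assay here.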

Compound 3, concentration for 50% growth inhibition: 7600 nM
Estimate against measurement, compound 3: 1.3-fold (0.10 log units) below, and the stated range covers the measured number.
By their numbers in this assay, from the lowest: compound 1; then compound 3; then compound 2.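

In this assay the change from 4-methoxyphenyl to 3,4-dimethoxyphenyl gives a 5.0-fold lower number from compound 2 to compound 3 (0.70 log units; beyond the scatter) and so, taken alone, strengthens growth inhibition, something the first two compounds could not show because they differ in more than one place. Compound 3 also isolates the other difference, since hydrogen in place of methyl on an aromatic carbon of the core gives a 3.6-fold higher number from compound 1 to compound 3 (0.56 log units; beyond the scatter) and weakens inhibition beyond the scatter. Both single changes therefore have a measurable share in the gap between compound 1 and compound 2, and the methoxy step is the larger of the two by its printed size, although nothing available here explains why either change acts as it does.

The compounds shown leave open whether methoxy itself matters on this aromatic carbon, or whether a hydroxy group, an ethoxy group or a fluorine atom in the same place would serve equally well. They also leave open whether methyl on the core is the best choice there, or whether a chlorine atom or an amine would give stronger or weaker growth inhibition.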